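A few compounds are considered here, and "the series" means these few. Any claim that something is new, unique, unknown or untested is made for them only; others in the source may bear on it.

Measured compounds in this set:
- compound 1, `COc1ccccc1CNc1ncnc2c1ncn2[C@@H]1O[C@H](CO)[C@@H](O)[C@H]1O` — 3200 nM
- compound 2, `OC[C@H]1O[C@@H](n2cnc3c(NCc4cc(F)cc(F)c4)ncnc32)C(O)C1O` — 24500 nM

Both numbers come from a functional assay on CCRF-CEM cells (Homo sapiens) for antiproliferative activity, with a stated time of 72 h; a higher number here means a weaker inhibitor, a lower number a stronger inhibitor. Compound 1 holds the lowest number of the two; its nearest neighbour is compound 2, whose number is higher by a margin that lies beyond the usual scatter, so compound 1 is the stronger of the pair in this assay on what has been measured.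

The unmeasured compound 3, `OC[C@H]1O[C@@H](n2cnc3c(NCc4ccc(F)c(Cl)c4)ncnc32)[C@H](O)[C@@H]1O`, shares the core of compound 1 and differs from it in one place: 3-chloro-4-fluorophenyl in place of 2-methoxyphenyl on a saturated chain carbon bound to a nitrogen on an aromatic ring. Within the data shown here, no pair of measured compounds differs in exactly one place, so the size of this kind of step has not been observed directly. Among the measured compounds shown here, the only guide is that compound 2, which also carries a halogenated ring in this position, gives 24500 nM, a weaker result than compound 1.

The step from compound 1 to compound 3 in this assay is therefore expected to run toward a higher number, a 2.5-fold higher number from compound 1 to compound 3 (0.40 log units; beyond the scatter), though a result within the scatter cannot be excluded. For compound 3 the estimated value in this assay is 8000 nM, with a range from 2500 nM to 25000 nM.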

Compound 3, half-maximal inhibitory concentration: 3400 nM
Compound 3: middle estimate off by 2.4-fold (0.37 log units), on the high side, and the stated range covers the measured number.
By their numbers in this assay, from the lowest: compounds 1 and 3 (each within the scatter of the next); then compound 2.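

On a saturated chain carbon bound to a nitrogen on an aromatic ring, putting 3-chloro-4-fluorophenyl in place of 2-methoxyphenyl gives a 1.1-fold higher number from compound 1 to compound 3 (0.03 log units; within the scatter) in this assay, the first single-place step readable in this series. Among these compounds, in this pair, the hydrogen-bond acceptor counted for 2-methoxyphenyl has no counterpart in 3-chloro-4-fluorophenyl, yet the two numbers stay within the scatter, so a halogenated ring at this position and a methoxy-bearing ring can give matching numbers on the shared core. Nothing on hand speaks to why these two different rings give such close numbers.

Steps involving compound 2 cannot be read, as it is linked to neither compound 1 nor compound 3 by a change in one place, so what lies behind its separate number remains unresolved. Also open, as far as these compounds go, is how far this tolerance extends, for instance whether an unsubstituted phenyl, a ring carrying an amine or a carboxylic acid, or a longer chain between the nitrogen and the ring would keep the number in the same range.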